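Replacing the formylphenyl arm: compound 2 to compound 3

A few compounds are considered here, and "the series" means these few. Any claim that something is new, unique, unknown or untested is made for them only; others in the source may bear on it.

Compound 2 `O=Cc1ccc(-c2cn3ccnc3c(-c3ccc4ncn(C5CCCCC5)c4c3)n2)cc1` holds the highest of the two numbers measured in a functional assay on UO-31 cells (Homo sapiens) for inhibition, read by sulforhodamine B assay, with a stated time of 48 h, tested at 10 uM (a lower number here means less inhibition, a higher number more inhibition at the concentration tested (going by the name of the read-out)), where compound 2 gives 82.2%; the nearest is compound 1 `Brc1cn2ccnc2c(-c2ccc3ncn(C4CCCCC4)c3c2)n1`, which gives 37.6%. Within the data shown here, compound 3 `c1ccc2c(-c3cn4ccnc4c(-c4ccc5ncn(C6CCCCC6)c5c4)n3)cccc2c1` is not yet measured. naphthalen-1-yl in place of 4-formylphenyl on an aromatic carbon The only step that bears on this change is a number 44.6 percentage points higher from compound 1 to compound 2 (beyond the scatter), which shows that an aryl group at this position lifts inhibition far above bromo. Naphthalen-1-yl keeps an aryl group but drops the formyl acceptor, so compound 3 is expected to stay clearly above compound 1, with a moderate fall estimated from compound 2, a number 17.2 percentage points lower from compound 2 to compound 3 (beyond the scatter). Compound 3 is therefore estimated at 65%, between 35% and 90%.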

Compound 3, a percentage reported as inhibition, at one concentration (the size of the read-out at that concentration, not a potency): 23%
Compound 3: the middle estimate sits 42 percentage points above what was measured, and the stated range ends above it.
By their numbers in this assay, from the lowest: compound 3; then compound 1; then compound 2.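

In this assay, putting naphthalen-1-yl in place of 4-formylphenyl gives a number 59.2 percentage points lower from compound 2 to compound 3 (beyond the scatter) and so removes the gain seen earlier. Set against bromo, the same group gives a number 14.6 percentage points lower from compound 1 to compound 3 (beyond the scatter) at this aromatic carbon. An aryl group here therefore does not lift inhibition by itself, and among these compounds only 4-formylphenyl does so. No measurement on hand accounts for this difference between the two aryl groups.

The compounds shown leave open whether a plain phenyl, a 4-hydroxymethylphenyl or a 4-carboxyphenyl would hold the number of compound 2. They also leave open whether the carbonyl or the single ring matters more.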